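The source may hold more compounds than are shown below. What is called first, only, known or untested is meant among the compounds shown, and "the series" means these compounds.

Measured so far:
Compound 1 `O=C(/C=C/c1ccc(OCc2cn(Cc3ccc(Br)cc3)nn2)cc1)c1ccc(Br)cc1` gives 22% in a functional assay on HepG2 cells (Homo sapiens) for inhibition, read by MTT assay, with a stated time of 48 h, tested at 10 uM; a lower number here means less inhibition of growth, a higher number more inhibition of growth at the concentration tested.
Compound 2 `O=C(/C=C/c1ccc(OCc2cn(Cc3cccc(F)c3)nn2)cc1)c1ccc(Br)cc1` gives 34% in this assay.
Compound 3 `O=C(/C=C/c1ccc(OCc2cn(Cc3ccc(F)cc3)nn2)cc1)c1ccc(Br)cc1` gives 22% in this assay.

For the measured compounds named here, compound 1 stands level with compound 3 at the low end of the three numbers; the only number beyond the scatter is that of compound 2, seen in a number 12 percentage points higher from compound 1 to compound 2 (beyond the scatter). The step of no change at the digits printed from compound 1 to compound 3 (within the scatter) stays within the scatter.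

Compound 4 `COc1ccc(C(=O)/C=C/c2ccc(OCc3cn(Cc4ccc(Br)cc4)nn3)cc2)cc1` differs from compound 1 by methoxy in place of bromo on an aromatic carbon, that is, (4-bromophenyl)carbonyl to (4-methoxyphenyl)carbonyl. Going by the values given here, none of the measured steps touches this part of the shared core: a number 12 percentage points higher from compound 1 to compound 2 (beyond the scatter) and no change at the digits printed from compound 1 to compound 3 (within the scatter) both alter the group on the saturated chain carbon bound to the aromatic nitrogen, and the larger of them is only modest. Among the compounds with values here, no direct precedent for a change on the carbonyl-side ring exists in this set, so the expectation is a step in this assay of no more than the modest size seen elsewhere, direction uncertain. Compound 4 is estimated at 25% (range 10% to 42%), which is expected to mean a number 3 percentage points higher from compound 1 to compound 4 (within the scatter).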

Compound 4, percent growth inhibition at one concentration: 59%
The estimate for compound 4 lay 34 percentage points below the measured number; measured number outside the range, above it.
By their numbers in this assay, from the lowest: compounds 1 and 3 (each within the scatter of the next); then compound 2; then compound 4.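

The ring on the carbonyl side is a position that responds in this assay: methoxy in place of bromo, on an aromatic carbon para to a large group, gives a number 37 percentage points higher from compound 1 to compound 4 (beyond the scatter) and so moves this read-out strongly. That large step exceeds the modest a number 12 percentage points higher from compound 1 to compound 2 (beyond the scatter) and the unchanged no change at the digits printed from compound 1 to compound 3 (within the scatter) on the group at the saturated chain carbon bound to the aromatic nitrogen, though the position rests on this one pair alone. No measurement in hand accounts for the step.

On these data alone, whether a hydroxy group, an amine or a longer alkoxy chain at this place would differ from methoxy remains open. Also open, as far as these compounds go, is whether methoxy gives a step of similar size on the 3-fluorophenyl background of compound 2.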